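Taking the methyl off compound 2

This account rests on a few compounds, and the source may have more. Where it says the series, first, only, none or still open, it means among the compounds named here.

In a functional assay on SiHa cells (Homo sapiens) for inhibition, read by sulforhodamine B assay (a higher number here means a weaker inhibitor of growth, a lower number a stronger inhibitor of growth), compound 1 (`Cc1ccc2[nH]c(-c3ccc(-c4ccc(-c5ccc(N(C)C)cc5)cc4)cc3)nc2c1`) stands at 7110 nM and compound 2 (`Cc1ccc2[nH]c(-c3ccc(-c4ccc(-c5cccc(Cl)c5)cc4)cc3)nc2c1`) at 3600 nM with the two lying within the scatter of each other. Compound 2 therefore cannot be ranked apart from compound 1 on these numbers.

Compound 3 (`Clc1cccc(-c2ccc(-c3ccc(-c4nc5ccccc5[nH]4)cc3)cc2)c1`) differs from compound 2 by hydrogen in place of methyl on an aromatic carbon. Going by the values given here, no measured step touches that methyl, since compound 1 and compound 2 both carry it, and the data hold no direct reading of its loss. Among the compounds with values here, the only measured step is a 2.0-fold lower number from compound 1 to compound 2 (0.30 log units; within the scatter) and it exchanges 4-(dimethylamino)phenyl for 3-chlorophenyl. That exchange replaces far more of the structure than the loss of a methyl does, yet it lies within the scatter. In this assay no step beyond the scatter is therefore expected for compound 3 and no direction can be named. The estimated step is a 1.1-fold higher number from compound 2 to compound 3 (0.05 log units; within the scatter) and it is expected to remain within the scatter. The estimated value for compound 3 is 4000 nM with an expected range from 1600 nM to 10000 nM for repeat measurements.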

Compound 3, concentration for 50% growth inhibition: 100000 nM
Compound 3: the middle estimate sits 25-fold (1.40 log units) below what was measured; measured number above the stated range.
By their numbers in this assay, from the lowest: compounds 2 and 1 (each within the scatter of the next); then compound 3.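

In this assay, going by these compounds alone, the methyl on the aromatic carbon of the fused system turns out to carry far more weight than the earlier compounds could show: a 28-fold higher number from compound 2 to compound 3 (1.44 log units; beyond the scatter) for the loss of a single heavy atom, one carbon, with no hydrogen-bond donor or acceptor leaving. Compound 1 and compound 2 both hold that methyl, so the exchange of 4-(dimethylamino)phenyl for 3-chlorophenyl between them, which stayed within the scatter, said nothing about this position. Among the compounds shown, this is the only single change that moves the number beyond the scatter, and nothing available speaks to why replacing methyl with hydrogen has so large an effect.

The compounds shown leave open whether growth inhibition depends on the methyl itself or on any group at that carbon, as only methyl and hydrogen appear there so far; an ethyl, a methoxy or a chloro group in the same place would separate these readings. Going by these compounds, it also remains open whether losing the methyl would matter as much in a compound carrying 4-(dimethylamino)phenyl instead of 3-chlorophenyl.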